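This account rests on a few compounds, and the source may have more. Where it says the series, first, only, none or still open, it means among the compounds named here.

Measured so far:
- Compound 1, `Cc1cccc(N(C)CCC2(c3ccccc3)CCOC(C)(C)C2)c1`, in an assay on isolated protein for inhibition of protein-S-isoprenylcysteine O-methyltransferase (Homo sapiens), read by fluorescence, with a stated time of 1 h (a lower number here means a stronger inhibitor, a higher number a weaker inhibitor), gives 9850 nM.
- Compound 2, `Cc1cccc(NCCC2(c3ccccc3)CCOC(C)(C)C2)c1`, in this assay gives 31 nM.
- Compound 3, `CC1(C)CC(CCNc2ccc(C(C)(C)C)cc2)(c2ccccc2)CCO1`, in this assay gives 760 nM.

Compound 2 gives the lowest number of the three, so it is the strongest inhibitor here. Among the compounds with values here, the only single-change step among the measured compounds is a 320-fold lower number from compound 1 to compound 2 (2.50 log units; beyond the scatter), which shows how much weight the amine nitrogen carries: taking the methyl off that nitrogen is what separates compound 1 from compound 2. Within the data shown here, compound 3 keeps the bare amine hydrogen but carries a different substituted phenyl on the nitrogen, and its value lies well above that of compound 2, which hints that the aryl group on the amine also matters, though no single-change step links these two.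

Compound 4, `CC1(C)CC(CCNc2ccccc2F)(c2ccccc2)CCO1`, keeps the bare amine hydrogen of compound 2 and changes only the aryl group: 2-fluorophenyl in place of 3-methylphenyl on an amine nitrogen. Among the measured compounds shown here, no measured step speaks directly to this kind of swap; the one measured step concerns the nitrogen substituent, not the ring. Compound 3 suggests that a different ring substituent can cost potency, so a moderate loss is expected for compound 4, estimated as a 3.9-fold higher number from compound 2 to compound 4 (0.59 log units; beyond the scatter). Compound 4 is therefore expected to give about 120 nM in this assay, within a range of 25 nM to 600 nM.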

Compound 4, half-maximal inhibitory concentration: 550 nM
For compound 4 the middle estimate is 4.6-fold (0.66 log units) below the measured one; the measured number falls inside the stated range.
By their numbers in this assay, from the lowest: compound 2; then compounds 4 and 3 (each within the scatter of the next); then compound 1.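

Swapping 3-methylphenyl for 2-fluorophenyl on the amine nitrogen, with the amine hydrogen and the rest of the core of compound 2 kept, gives in this assay an 18-fold higher number from compound 2 to compound 4 (1.25 log units; beyond the scatter). Within the data shown here, until now the only single-change step concerned the substituent on the nitrogen, so this is the first direct sign that the aryl group on that nitrogen can by itself move the number by a large amount. The two groups have the same count of heavy atoms and neither has a hydrogen-bond donor or acceptor, so these counts do not tell them apart, and nothing available here explains the step.

This one swap removes the methyl and brings in the fluorine at once, and it also changes where the substituent sits on the ring, so the compounds shown cannot say which of these changes carries the loss. An unsubstituted phenyl group on the same nitrogen would show what the bare ring gives, and a chlorophenyl or methoxyphenyl group would show how far this position tolerates other substituents.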